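The source may report more compounds than this note shows. Statements on the series, on what has been measured and on what is new or still open speak of the compounds shown alone.

Compound 1 `CSc1ccc(C2=C(c3ccc(C)c(C)c3)C(=O)N3CCCC3C2)cc1`: 10000 nM
Compound 2 `CSc1ccc(C2=C(c3ccc(F)c(C)c3)C(=O)N3CCCC3C2)cc1`: 200 nM

Going by the values given here, in a functional assay on U-251 cells (Homo sapiens) for cytotoxicity (on this read-out higher numbers stand for weaker inhibition of growth and lower numbers for stronger inhibition of growth), compound 2 gives 200 nM, the lower of the two numbers so far. Compound 3 `CSc1ccc(C2=C(c3ccc(O)cc3)C(=O)N3CCCC3C2)cc1` has 4-hydroxyphenyl in place of 4-fluoro-3-methylphenyl on a double-bonded ring carbon. Among the compounds with values here, only one measured step bears on this change: a 50-fold lower number from compound 1 to compound 2 (1.70 log units; beyond the scatter), a large step for fluoro in place of methyl in this same group. Within the data shown here, no measured compound carries 4-hydroxyphenyl, so that step shows only that changes here can matter. With compound 2 at the low end, a clear move towards a higher number is expected, estimated as a 4.0-fold higher number from compound 2 to compound 3 (0.60 log units; beyond the scatter). For compound 3 the estimate is 800 nM, with an expected range of 120 nM to 6000 nM.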

Compound 3, concentration for 50% growth inhibition: > 100000 nM
Compound 3 ended at the assay's limit; the forecaster's own chance of this, stated with the estimate: 10%; middle value at least 120-fold (2.09 log units) away from the limit.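

Compound 3 stands at a limit of the assay, not at a number: the limit of > 100000 nM in this assay, at which 1 of the 3 values shown sits.

Even so, this assay shows an at least 500-fold higher number from compound 2 to compound 3 (2.69 log units; beyond the scatter), and also an at least 10-fold higher number from compound 1 to compound 3 (1.00 log units; beyond the scatter). Going by these compounds alone, the earlier pair showed only that a small swap on this aromatic group can move the number, whereas 4-hydroxyphenyl on this double-bonded ring carbon gives a higher number than both the fluoro and the dimethyl compounds.

On these data alone, it stays open whether the hydroxyl or the lost methyl accounts for these steps, and how an amine or a carboxylic acid here would read.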